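From Ethyl to Isopropyl at the Aromatic Nitrogen

The source may hold more compounds than are shown below. What is called first, only, known or untested is meant among the compounds shown, and "the series" means these compounds.

Compound 2 `CCn1ccnc1-c1cccc(Cl)c1CCc1cc(Br)ccc1OC` gives 1800 nM in a functional assay on HEK293 cells (Homo sapiens), read by cAMP accumulation (on this read-out lower numbers stand for stronger inhibition and higher numbers for weaker inhibition), the larger of the two numbers at hand, though only by a gap that the scatter covers. Among the compounds with values here, its sole neighbour is compound 1 `COc1ccc(Br)cc1CCc1c(Cl)cccc1-c1nccn1C`, which gives 1100 nM in this assay. Within the data shown here, the one measured step, a 1.6-fold higher number from compound 1 to compound 2 (0.21 log units; within the scatter), came from methyl in place of hydrogen on a saturated chain carbon bound to an aromatic nitrogen. Compound 3 `COc1ccc(Br)cc1CCc1c(Cl)cccc1-c1nccn1C(C)C` carries the change (methyl in place of hydrogen on a saturated chain carbon bound to an aromatic nitrogen and a saturated chain carbon); the same difference, cut one bond further out, reads ethyl to isopropyl. This is the same kind of addition as the measured step, which brought nothing beyond the scatter, so the step to compound 3 is expected to be small as well, a 1.3-fold higher number from compound 2 to compound 3 (0.11 log units; within the scatter) in this assay, with a mild lean toward a higher number. Compound 3 is therefore estimated at 2300 nM, within a range from 900 nM to 6000 nM.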

Compound 3, half-maximal inhibitory concentration: 1400 nM
For compound 3 the middle estimate is 1.6-fold (0.22 log units) above the measured one; the range from low to high includes it.
By their numbers in this assay, from the lowest: compounds 1, 3 and 2 (each within the scatter of the next).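

The second methyl, which turns ethyl into isopropyl on a saturated chain carbon bound to an aromatic nitrogen and a saturated chain carbon, gives a 1.3-fold lower number from compound 2 to compound 3 (0.11 log units; within the scatter) in this assay, so this addition, like the earlier one, stays within the scatter. Read directly, isopropyl in place of methyl on an aromatic nitrogen gives a 1.3-fold higher number from compound 1 to compound 3 (0.10 log units; within the scatter), which means that methyl, ethyl and isopropyl at this nitrogen cannot be told apart by their numbers. Nothing available explains why the three numbers stay so close. Methyl, ethyl and isopropyl are all plain saturated chains, so it remains open how a longer chain such as butyl, a benzyl group or a chain ending in an amine or a carboxylic acid would read at this nitrogen. From the compounds shown here alone, it also remains open whether this closeness would hold with the bromine or the chlorine of the shared core replaced.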